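From a methanesulfonamido phenyl to a pyridyl ring

The compounds below may be only part of what the source reports. "The series", "measured", "known", "first", "only" and "open" are said of these compounds alone.

Of the compounds shown here, three built on one shared core have been measured in an in vitro functional assay on HEK285-7 cells for antagonist activity at prostaglandin D2 receptor 2 (Homo sapiens), read by BRET and beta-arrestin recruitment; on this read-out higher numbers stand for weaker inhibition and lower numbers for stronger inhibition. Compound 1 `O=C(O)Cc1sc(C(c2ccc(F)cc2)c2ccc(F)cc2)nc1-c1ccc(Cl)cc1` gives 180 nM, compound 2 `NS(=O)(=O)c1cccc(-c2nc(C(c3ccc(F)cc3)c3ccc(F)cc3)sc2CC(=O)O)c1` gives 710 nM, and compound 3 `CS(=O)(=O)Nc1cccc(-c2nc(C(c3ccc(F)cc3)c3ccc(F)cc3)sc2CC(=O)O)c1` gives 370 nM. Compound 3 thus stands second highest of the three numbers: the step of a 1.9-fold lower number from compound 2 to compound 3 (0.28 log units; within the scatter) lies within the scatter, whereas the step of a 2.1-fold higher number from compound 1 to compound 3 (0.31 log units; beyond the scatter) lies beyond it. The remaining step, a 3.9-fold higher number from compound 1 to compound 2 (0.60 log units; beyond the scatter), is of the same modest kind.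

Compound 4 `O=C(O)Cc1sc(C(c2ccc(F)cc2)c2ccc(F)cc2)nc1-c1ccncc1` has not yet been measured in this assay. It differs from compound 3 in a single place: pyridin-4-yl in place of 3-(methanesulfonamido)phenyl on an aromatic carbon. Among the measured compounds shown here, no measured step exchanges a phenyl ring for a pyridine ring, so the only guide is how this assay responded when the aryl group at this position was varied, namely a 3.9-fold higher number from compound 1 to compound 2 (0.60 log units; beyond the scatter) and a 2.1-fold higher number from compound 1 to compound 3 (0.31 log units; beyond the scatter), both modest. A modest step is thus expected here as well, a 1.1-fold higher number from compound 3 to compound 4 (0.03 log units; within the scatter), with no firm direction. Compound 4 is therefore estimated at 400 nM in this assay, with a range from 130 nM to 1200 nM.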

Compound 4, half-maximal inhibitory concentration: 40 nM
The estimate for compound 4 lay 10-fold (1.00 log units) above the measured number; measured number below the stated range.
By their numbers in this assay, from the lowest: compound 4; then compound 1; then compounds 3 and 2 (each within the scatter of the next).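

In this assay, the aryl group on the aromatic carbon next to the ring nitrogen proves able to move the number down as well as up: both earlier replacements of 4-chlorophenyl raised it, whereas pyridin-4-yl gives a 4.5-fold lower number from compound 1 to compound 4 (0.65 log units; beyond the scatter). Among the compounds shown here, the position also has a wider span than the earlier steps showed, with a 9.3-fold lower number from compound 3 to compound 4 (0.97 log units; beyond the scatter) and, the only large step in the set, an 18-fold lower number from compound 2 to compound 4 (1.25 log units; beyond the scatter), so that the entering group, which has fewer heavy atoms than 3-(methanesulfonamido)phenyl and no hydrogen-bond donor, sets the lowest number of the four. Nothing available here accounts for this drop, and the data offer no independent measurement that bears on it.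

The compounds shown leave open whether the ring nitrogen itself matters or whether the outcome simply follows from losing the sulfonamide and chloro substituents, a question that an unsubstituted phenyl ring or a pyridin-3-yl group at this position would help to settle. They also leave open whether the low number would survive a methyl group or an amine on the pyridine ring.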